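The compounds below may be only part of what the source reports. "The series", "measured", "known", "first", "only" and "open" are said of these compounds alone.

Working notes on the series. Among the measured compounds shown here, compound 2 `COc1ccc([C@@H]2C(c3cc4ccccc4n3C)C(=O)N2c2cc(OC)c(OC)c(OC)c2)cc1` stands at the highest of the two numbers so far in a functional assay on MCF7 cells (Homo sapiens) for antiproliferative activity, read by MTT assay; a higher number here means a weaker inhibitor, a lower number a stronger inhibitor: compound 2 gives 6600 nM. For the measured compounds named here, its nearest neighbour is compound 1 `COc1ccc([C@@H]2C(c3ccc(C)s3)C(=O)N2c2cc(OC)c(OC)c(OC)c2)cc1`, which in this assay gives 250 nM; the only measured step in the set is a 26-fold higher number from compound 1 to compound 2 (1.42 log units; beyond the scatter), and it lies well beyond the scatter.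

Compound 3 `COc1ccc([C@@H]2C(c3ccsc3)C(=O)N2c2cc(OC)c(OC)c(OC)c2)cc1` is not yet measured. It differs from compound 2 in one place: thiophen-3-yl in place of 1-methyl-1H-indol-2-yl on a saturated ring carbon. The step from compound 1 to compound 2 bears on this directly, because a 26-fold higher number from compound 1 to compound 2 (1.42 log units; beyond the scatter) describes the exchange of a thiophene group for the 1-methyl-1H-indol-2-yl group at the same saturated ring carbon of the shared core. Compound 3 returns that carbon to a thiophene, though thiophen-3-yl rather than 5-methylthiophen-2-yl, so a large step downward, roughly undoing the earlier step, is expected, with some allowance for the changed point of attachment. For compound 3 the expected number in this assay is 400 nM, with a range from 120 nM to 1500 nM. The expected step is a 17-fold lower number from compound 2 to compound 3 (1.22 log units; beyond the scatter), downward and beyond the scatter.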

Compound 3, half-maximal inhibitory concentration: 60 nM
Compound 3: middle estimate off by 6.7-fold (0.82 log units), on the high side; the measured number lies below the stated range.
By their numbers in this assay, from the lowest: compound 3; then compound 1; then compound 2.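

In this assay, the saturated ring carbon of the four-membered ring responds even more strongly to the group it carries than the first step suggested: replacing 1-methyl-1H-indol-2-yl with thiophen-3-yl gives a 110-fold lower number from compound 2 to compound 3 (2.04 log units; beyond the scatter), a larger change than the earlier one in the opposite direction. The two thiophene compounds also differ from each other, with a 4.2-fold lower number from compound 1 to compound 3 (0.62 log units; beyond the scatter), so the result at this carbon depends on more than the presence of a thiophene, and compound 3 is the strongest inhibitor of the three. That second step changes both the point of attachment and the methyl group at once, so the compounds shown cannot assign it to either change, and no supporting evidence bears on why these groups differ.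

Unsubstituted thiophen-2-yl and 5-methylthiophen-3-yl would separate those two changes, while 1-methyl-1H-indol-3-yl would show whether the weak result of compound 2 is tied to its attachment point. Going by these compounds, it also remains open how this carbon responds to groups of another kind, such as phenyl, furan-3-yl, an aminomethyl group or a carboxylic acid.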